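A few compounds are considered here, and "the series" means these few. Any claim that something is new, unique, unknown or untested is made for them only; others in the source may bear on it.

This account concerns three measured compounds and a fourth whose result is still to come, all sharing the same core. Compound 1 `COc1cc(C2=NN(C(C)=O)C(c3c(Cl)cccc3Cl)O2)cc(OC)c1OC` carries a five-membered non-aromatic ring with 2 nitrogen and 1 oxygen, bearing an acetyl group, and a 2,6-dichlorophenyl group on a saturated ring carbon. In a functional assay on PC-3 cells (Homo sapiens) for antiproliferative activity, read by MTT assay, tested at 1 uM (a higher number here means a stronger effect of the compound at the concentration tested, a lower number a weaker effect), compound 1 gives 5.1%. Two compounds built differently give higher numbers: compound 2 `COc1cc(C(=O)N/N=C/c2ccccc2C(F)(F)F)cc(OC)c1OC` gives 45% in this assay, and compound 3 `COc1cc(C(=O)N/N=C/c2cccc(F)c2)cc(OC)c1OC` gives 53.5%. Compound 1 thus stands lowest of the three, its nearest neighbour being compound 2, whose number lies beyond the usual scatter above it, while compound 3 lies further still.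

The unmeasured compound 4 `COc1cc(C2=NN(C(C)=O)C(c3ccc(F)cc3)O2)cc(OC)c1OC` differs from compound 1 in one place: 4-fluorophenyl in place of 2,6-dichlorophenyl on a saturated ring carbon. Within the data shown here, no pair of measured compounds differing in just this place is available, so the size of the step has to be expected rather than read. Since compound 1 sits so low with 5.1%, a move upward seems more likely than a move further down, but only a modest one. The step of a number 9.9 percentage points higher from compound 1 to compound 4 (within the scatter) is expected to be small and upward, at about the edge of the usual scatter. Compound 4 is accordingly expected to give 15%, with a range from 0% to 40%.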

Compound 4, a percentage reported as inhibition, at one concentration (the size of the read-out at that concentration, not a potency): 0%
Compound 4: middle estimate off by 15 percentage points, on the high side; the measured number falls inside the stated range.
By their numbers in this assay, from the lowest: compounds 4 and 1 (each within the scatter of the next); then compounds 2 and 3 (each within the scatter of the next).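

In this assay, among these compounds, placing 4-fluorophenyl instead of 2,6-dichlorophenyl on the saturated ring carbon gives a number 5.1 percentage points lower from compound 1 to compound 4 (within the scatter), the first step at this position that can be read directly. For this pair of groups, the read-out therefore does not separate the two aryl substituents, even though they differ in the number and kind of halogen atoms they carry; this single step shows no measurable dependence on that exchange. Nothing available offers an explanation for this result.

The compounds shown leave open whether any other group on this saturated ring carbon, such as an unsubstituted phenyl, a 4-methoxyphenyl or a pyridine ring, would give a number beyond the scatter of these two. They also leave open what happens when the acetyl group on the neighbouring ring atom gives way to a longer acyl chain such as propionyl or to a plain hydrogen, and, with only a single concentration read, how these two compounds would behave at other concentrations.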